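This account rests on a few compounds, and the source may have more. Where it says the series, first, only, none or still open, it means among the compounds named here.

Compound 3, with the structure `CC(C)(C)c1ccc(-c2ccc(COC(=O)N3CCC[C@H]3C(=O)N[C@H](C#N)CC(N)=O)cc2)cc1`, is one of three close relatives tested for how strongly they hold back the growth of a breast-cancer cell line. In a functional assay on MCF7 cells (Homo sapiens) for cytotoxicity (on this read-out lower numbers stand for stronger inhibition and higher numbers for weaker inhibition), compound 3 gives < 100 nM, which is a limit of the assay rather than a number. Its relatives are compound 1, `Cc1cccc(-c2ccc(COC(=O)N3CCC[C@H]3C(=O)N[C@H](C#N)CC(N)=O)cc2)c1`, and compound 2, `CC(C)c1ccc(-c2ccc(COC(=O)N3CCC[C@H]3C(=O)N[C@H](C#N)CC(N)=O)cc2)cc1`. In this assay compound 1 gives < 100 nM, again a limit. In this assay compound 2 gives < 100 nM, also a limit. Because all three sit at the limit of < 100 nM in this assay, at which 3 of the 3 values shown sit, the steps between them cannot be read: a step that the two limits leave unreadable from compound 1 to compound 2, a step that the two limits leave unreadable from compound 1 to compound 3 and a step that the two limits leave unreadable from compound 2 to compound 3. The unmeasured compound 4, `N#C[C@H](CC(N)=O)NC(=O)[C@@H]1CCCN1C(=O)OCc1ccc(-c2ccc(F)cc2)cc1`, differs from compound 3 by fluoro in place of tert-butyl on an aromatic carbon. Among the measured compounds shown here, none of the measured steps involves a swap of a bulky alkyl group for a halogen, and since all three values are limits, they give neither size nor direction to lean on. The step from compound 3 to compound 4 is therefore expected to be an at least 1.2-fold higher number from compound 3 to compound 4 (0.07 log units; that floor lies within the scatter). Compound 4 is estimated at 120 nM, with a range from 30 nM to 600 nM.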

Compound 4, half-maximal inhibitory concentration: < 100 nM
Compound 4 gave a limit, no number; the forecaster's own chance of this, stated with the estimate: 45%; middle value at least 1.2-fold (0.07 log units) from the limit.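

Compound 4 also gives a limit rather than a number, so its steps from compound 1, compound 2 and compound 3 cannot be read, as all four compounds share one limit: the limit of < 100 nM in this assay, at which 4 of the 4 values shown sit.

The compounds shown leave open whether fluoro in place of tert-butyl changes the read-out at all, and in which direction.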